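A tert-butoxycarbonyl group on a longer chain

The compounds below may be only part of what the source reports. "The series", "measured", "known", "first", "only" and "open" are said of these compounds alone.

Three measured compounds share one core and differ only in the group on the amine nitrogen in a ring. Among the compounds with values here, in a functional assay (strain AB) with Danio rerio as the target, read by microscopy, with a stated time of 1 h (a higher number here means that more compound is needed for the effect, a lower number that less compound is needed), compound 3 `COCCCN1CCc2c(sc(NC(=O)Nc3ccc(Cl)cc3)c2C(N)=O)C1` gives 2400 nM, the lowest of the two actual numbers so far. Compound 1 `CC(C)(C)CN1CCc2c(sc(NC(=O)Nc3ccc(Cl)cc3)c2C(N)=O)C1`, the nearest, gives 5560 nM, and the two are separated by a 2.3-fold lower number from compound 1 to compound 3 (0.36 log units; beyond the scatter). Compound 2 `CC(C)(C)OC(=O)CN1CCc2c(sc(NC(=O)Nc3ccc(Cl)cc3)c2C(N)=O)C1` gives > 25000 nM, which is a limit of the assay and not a number.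

Compound 4 `CC(C)(C)OC(=O)CCCCN1CCc2c(sc(NC(=O)Nc3ccc(Cl)cc3)c2C(N)=O)C1` changes the end of the chain of compound 3: (tert-butoxycarbonyl)methyl in place of methoxy on a saturated chain carbon, three bonds along the chain from an amine nitrogen in a ring. In words, this is (tert-butoxycarbonyl)methyl in place of methoxy, so 3-methoxypropyl becomes 4-(tert-butoxycarbonyl)butyl.

The closest evidence concerns the tert-butoxycarbonyl group itself. Putting it in place of tert-butyl gave an at least 4.4-fold higher number from compound 1 to compound 2 (0.65 log units; beyond the scatter), and putting 2-methoxyethyl in its place gave an at least 10-fold lower number from compound 2 to compound 3 (1.01 log units; beyond the scatter). Within the data shown here, both steps point to a higher number with this group, but no measured compound carries it on so long a chain. A rise in this assay is therefore expected, smaller than the large reverse of an at least 10-fold lower number from compound 2 to compound 3 (1.01 log units; beyond the scatter). The expected change is a 2.9-fold higher number from compound 3 to compound 4 (0.46 log units; beyond the scatter). For compound 4 the estimated value is 7000 nM, with an expected range from 2000 nM to 25000 nM.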

Compound 4, half-maximal effective concentration: 710 nM
Beside the measured number, compound 4's estimate is 9.9-fold (0.99 log units) above it; the measured number lies below the stated range.
By their numbers in this assay, from the lowest: compound 4; then compound 3; then compound 1. At a limit, above all of these: compound 2.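

The tert-butoxycarbonyl group does not bring a higher number wherever it sits: in this assay, the change from 3-methoxypropyl to 4-(tert-butoxycarbonyl)butyl gives a 3.4-fold lower number from compound 3 to compound 4 (0.53 log units; beyond the scatter), and against the tert-butyl-bearing chain the result is a 7.8-fold lower number from compound 1 to compound 4 (0.89 log units; beyond the scatter), which makes compound 4 the lowest of the compounds shown. The earlier compounds shown here tied this group to a poor result only when it sat close to the ring nitrogen, and lengthening the chain that carries it gives an at least 35-fold lower number from compound 2 to compound 4 (1.54 log units; beyond the scatter), so the same group behaves very differently at the two distances. Compound 2 stands at a limit and not at a number, so this last step gives only a bound on the gap: the limit of > 25000 nM in this assay, at which 1 of the 4 values shown sits.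

Going by these compounds, what remains open is how the number changes with chain length, for instance with 2-(tert-butoxycarbonyl)ethyl or with a longer chain ending in the same group. On these data alone, it is also open whether the whole tert-butoxycarbonyl group matters at the chain end, or whether a carboxylic acid, a methyl ester or an amine at that end would give a similar number.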